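Series notes: cyanoazetidine ethers, step toward compound 3

The source may report more compounds than this note shows. Statements on the series, on what has been measured and on what is new or still open speak of the compounds shown alone.

Compound 2 `N#CN1CC(OCc2ccc(Oc3ccccc3)cc2)C1` gives in an assay on isolated protein for inhibition of N-acylethanolamine-hydrolyzing acid amidase (Homo sapiens), read by fluorescence, with a stated time of 90 min (on this read-out lower numbers stand for stronger inhibition and higher numbers for weaker inhibition), a value of 1.1 nM, which is the highest of the two numbers recorded so far; its nearest neighbour, compound 1 `N#CN1CC(OCc2ccc(-c3ccc(F)cc3)cc2)C1`, gives 0.68 nM in this assay. Within the data shown here, the only measured step, a 1.6-fold higher number from compound 1 to compound 2 (0.21 log units; within the scatter), lies within the scatter, so the two compounds cannot be ordered against each other. Compound 3 `N#Cc1ccc(-c2cc(Oc3ccccc3)ccc2COC2CN(C#N)C2)cc1` differs from compound 2 by 4-cyanophenyl in place of hydrogen on an aromatic carbon. Among the measured compounds shown here, no measured step touches that position of the shared core; the step from compound 1 to compound 2 concerns a change at another position and was itself within the scatter, so it gives no guide to size or direction here. The outcome for compound 3 in this assay is therefore expected only with wide uncertainty, with a somewhat higher number judged slightly more likely than a lower one. The estimate for compound 3 in this assay is 4 nM, with an expected range from 0.7 nM to 25 nM. This corresponds to an expected step of a 3.6-fold higher number from compound 2 to compound 3 (0.56 log units; beyond the scatter).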

Compound 3, half-maximal inhibitory concentration: 2.5 nM
Compound 3: the middle estimate sits 1.6-fold (0.20 log units) above what was measured; measured number inside the range.
By their numbers in this assay, from the lowest: compounds 1 and 2 (each within the scatter of the next); then compound 3.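

This position, on an aromatic carbon ortho to the ((1-cyanoazetidin-3-yl)oxy)methyl group and meta to the phenoxy group, gives the only step shown that lies beyond the scatter: in this assay there is a 2.3-fold higher number from compound 2 to compound 3 (0.36 log units; beyond the scatter) for 4-cyanophenyl in place of hydrogen. The step is modest, so the position accepts a group of 8 heavy atoms with one added aromatic ring, and compound 3 still reads 2.5 nM on this read-out. Nothing available accounts for the direction or size of this step.

From the compounds shown here alone, a single group at this position sets no trend, so it stays open how a methyl, a phenyl without the nitrile, or an aminomethyl-bearing phenyl would read here. Also open, going by these compounds, is whether 4-cyanophenyl would give a similar step on the core of compound 1.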